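A Chlorophenyl in Place of a Bromofuran

The source may report more compounds than this note shows. Statements on the series, on what has been measured and on what is new or still open speak of the compounds shown alone.

The account starts from compound 1 `O=C(NO)c1ccc(NCc2nc(-c3ccc(Br)o3)nn2-c2ccccc2)cc1`. In an assay on Sf9 cells for inhibition of protein deacetylase HDAC6 (Homo sapiens), read by fluorescence, with a stated time of 40 min, tested at 100 nM (on this read-out lower numbers stand for less inhibition and higher numbers for more inhibition at the one concentration tested (going by the name of the read-out)), compound 1 gives 55.8%. For the measured compounds named here, the only other measured compound, compound 2 `Cc1ccc(-n2nc(-c3ccccc3)nc2CNc2ccc(C(=O)NO)cc2)cc1`, gives 60.7% in this assay. Compound 1 thus stands alongside compound 2, since the gap between the two numbers lies within the usual scatter of repeated measurements, and neither compound can be set apart from the other on these data. Going by the values given here, no pair of measured compounds differs in a single place, so no measured step is available to guide the next change.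

The unmeasured compound 3 `O=C(NO)c1ccc(NCc2nc(-c3cccc(Cl)c3)nn2-c2ccccc2)cc1` is compound 1 with one change: 3-chlorophenyl in place of 5-bromofuran-2-yl on an aromatic carbon. Among the compounds with values here, one halogenated aromatic group gives way to another of nearly the same size, and nothing among the measured compounds suggests that this kind of swap moves the read-out far. Compound 3 is therefore expected to give 55%, with a range from 35% to 72%. The expected step is a number 0.8 percentage points lower from compound 1 to compound 3 (within the scatter), that is, no change beyond the scatter.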

Compound 3, a percentage reported as inhibition, at one concentration (the size of the read-out at that concentration, not a potency): 61.2%
Compound 3: the middle estimate sits 6.2 percentage points below what was measured, and the stated range covers the measured number.
By their numbers in this assay, from the lowest: compounds 1, 2 and 3 (each within the scatter of the next).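

In this assay, for the compounds shown here, putting 3-chlorophenyl in place of 5-bromofuran-2-yl gives a number 5.4 percentage points higher from compound 1 to compound 3 (within the scatter), the first measured step at this aromatic carbon of the five-membered aromatic ring with 3 nitrogen. It shows that, for this one exchange, a five-membered aromatic ring with 1 hetero atom can give way to a six-membered aromatic ring of carbon only, and bromine to chlorine, without a change beyond the scatter in this read-out. No measurement presented here accounts for this result, and the step alone says nothing about what the position requires.

As far as these compounds go, both groups compared at this place are halogen-bearing aromatic rings, so it remains open whether the read-out would also hold with a group of another kind there, such as a primary amine, a carboxylic acid or a longer alkyl chain. From the compounds shown here alone, with a single concentration for each compound, it is also open whether potency would stay as close across this exchange as the percentages do.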